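Removing the dimethylamino group from compound 1

A few compounds are considered here, and "the series" means these few. Any claim that something is new, unique, unknown or untested is made for them only; others in the source may bear on it.

Compound 1, `CN(C)c1nc(NC2CCC(NS(=O)(=O)c3ccc(Br)cc3OC(F)(F)F)CC2)nc2ccccc12`, and compound 2, `CN(C)c1nc(NCC2CCC(CNS(C)(=O)=O)CC2)nc2ccccc12`, have both been tested in an assay on COS-1 cells for inhibition of Neuropeptide Y receptor type 5 (Homo sapiens); on this read-out higher numbers stand for weaker inhibition and lower numbers for stronger inhibition. In this assay compound 1 gives 31 nM, and compound 2 gives 41 nM. Compound 1 has the lower of the two numbers, but the gap to compound 2 is within the scatter, so the two compounds cannot be told apart on this read-out.

Compound 3, `O=S(=O)(NC1CCC(Nc2ncc3ccccc3n2)CC1)c1ccc(Br)cc1OC(F)(F)F`, has not yet been measured. It differs from compound 1 in one place: hydrogen in place of dimethylamino on an aromatic carbon. The dimethylamino group sits on a six-membered aromatic ring with two nitrogen atoms in the fused two-ring part of the shared core, and in compound 3 only a hydrogen remains there.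

Going by the values given here, no pair of measured compounds shows the effect of this change, and compound 2 differs from compound 1 in several places at once, so it gives no direct guidance. Removing a group of this size from an aromatic ring of the core often costs some potency, so a moderate weakening is expected, with a step of a 3.2-fold higher number from compound 1 to compound 3 (0.51 log units; beyond the scatter). Compound 3 is therefore estimated at 100 nM, with a range from 25 nM to 400 nM.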

Compound 3, half-maximal inhibitory concentration: 880 nM
Beside the measured number, compound 3's estimate is 8.8-fold (0.94 log units) below it; the whole stated range lies below it.
By their numbers in this assay, from the lowest: compounds 1 and 2 (each within the scatter of the next); then compound 3.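

Replacing the dimethylamino group with hydrogen on this aromatic carbon of the shared core gives a 28-fold higher number from compound 1 to compound 3 (1.45 log units; beyond the scatter) in this assay, a large step well beyond the scatter. Going by these compounds alone, this is the first direct reading at this position, and it shows that the position is far from indifferent to what it carries: losing just these 3 heavy atoms (2 carbon, 1 nitrogen) takes away most of the inhibition seen with compound 1. Nothing measured here explains why the step is so large, so the result records the size of the effect and not its cause.

As far as these compounds go, what the dimethylamino group contributes remains open: a primary amine, a methylamino group, a methoxy group or a pyrrolidine ring on the same carbon would show whether the nitrogen, the two methyl groups or simply the presence of a substituent matters most. Within the data shown here, it is also open whether removing the dimethylamino group would cost as much with a different side chain on the core, such as the one carried by compound 2.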